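Swapping the acyl group on a urea-sulfamide series

The source may report more compounds than this note shows. Statements on the series, on what has been measured and on what is new or still open speak of the compounds shown alone.

Compound 1 `CC(=O)NCCC1CCN(S(=O)(=O)NC(=O)NC[C@@H]2C[C@@H]3C=C[C@@H]2C3)CC1`: 25%
Compound 2 `Cc1ncsc1C(=O)NCCC1CCN(S(=O)(=O)NC(=O)NC[C@@H]2C[C@@H]3C=C[C@@H]2C3)CC1`: 25%
Compound 3 `Cn1cc(C(=O)NCCC2CCN(S(=O)(=O)NC(=O)NC3CCCCC3)CC2)c(=O)n(C)c1=O`: 15%

In a functional assay on the whole organism (blood) with Rattus norvegicus as the target, with stated times of 24 h and 1 h, at a dose of 15 mg/kg by the intraperitoneal route (a lower number here means a weaker effect, a higher number a stronger effect of the compound at the dose given), compound 3 gives the lowest of the three numbers, but both compound 1 and compound 2 lie only within the scatter of it, so no order among the three can be claimed. The unmeasured compound 4 `COc1ncccc1C(=O)NCCC1CCN(S(=O)(=O)NC(=O)NC2CCCCC2)CC1` differs from compound 3 at one place: a group of 8 heavy atoms (6 carbon, 1 nitrogen, 1 oxygen; one six-membered aromatic ring with 1 hetero atom) in place of a group of 10 heavy atoms (6 carbon, 2 nitrogen, 2 oxygen; one six-membered aromatic ring with 2 hetero atoms), on a carbonyl carbon. For the measured compounds named here, the only measured step of the same kind, a change on the carbonyl carbon, is the one from compound 1 to compound 2, which gave no change at the digits printed from compound 1 to compound 2 (within the scatter); it was made on a core different from that shared by compounds 3 and 4, so it guides the expectation only loosely. On that basis the step from compound 3 to compound 4 is expected to be a number 2 percentage points higher from compound 3 to compound 4 (within the scatter), that is, nothing beyond the scatter. Compound 4 is therefore estimated at 17%, within a range of 5% to 32%.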

Compound 4, a percentage reported as activity, at one dose (the size of the read-out at that dose, not a potency): 35%
Beside the measured number, compound 4's estimate is 18 percentage points below it, and the stated range ends below it.
By their numbers in this assay, from the lowest: compounds 3, 1, 2 and 4 (each within the scatter of the next, the first and the last beyond it).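

On the core shared by compounds 3 and 4, the group on the carbonyl carbon does matter in this assay: 2-methoxypyridin-3-yl in place of the ring with two hetero atoms gave a number 20 percentage points higher from compound 3 to compound 4 (beyond the scatter). For the compounds shown here, the earlier change at this kind of place, no change at the digits printed from compound 1 to compound 2 (within the scatter), showed no such effect, though it was made on a different core, so this is the first sign that the read-out at this dose responds to the group on the carbonyl carbon. Nothing available speaks to the reason for the step.

The compounds shown leave open whether the ring nitrogen or the methoxy group of the entering group carries the step, which a plain phenyl or a 2-methoxyphenyl group on the same carbonyl carbon would separate. Also open, from the compounds shown here alone, is whether 2-methoxypyridin-3-yl would give a similar step on the core of compound 1.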